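The source may hold more compounds than are shown below. What is called first, only, known or untested is meant among the compounds shown, and "the series" means these compounds.

Of the compounds shown here, two of one shared core have been measured in a functional assay on MCF7 cells (Homo sapiens) for antiproliferative activity, read by MTT assay, with a stated time of 72 h; a lower number here means a stronger inhibitor, a higher number a weaker inhibitor. Compound 1 `COc1ccc(N2C(=O)COc3ccc(-c4cnc(OC)c(NS(=O)(=O)c5ccc(F)cc5)c4)cc32)cc1` gives 8260 nM, the lowest of the two numbers shown. Going by the values given here, compound 2 `COc1ccc(N2C(=O)COc3ccc(-c4cnc(Cl)c(NS(=O)(=O)c5ccc(F)cc5)c4)cc32)cc1` gives 36000 nM; the only measured step, a 4.4-fold higher number from compound 1 to compound 2 (0.64 log units; beyond the scatter), comes from a chloro in place of methoxy on an aromatic carbon, far from the ring nitrogen that carries the aryl group.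

Compound 3 `COc1ncc(-c2ccc3c(c2)N(C(C)C)C(=O)CO3)cc1NS(=O)(=O)c1ccc(F)cc1` differs from compound 1 as follows: isopropyl in place of 4-methoxyphenyl on an amide-type nitrogen in a ring. No measured step touches that amide-type nitrogen, so the one step shown, a 4.4-fold higher number from compound 1 to compound 2 (0.64 log units; beyond the scatter), gives no direct guide. With nothing in the data to set a direction, the change is expected to give a step of a 1.5-fold higher number from compound 1 to compound 3 (0.16 log units; within the scatter), within the usual scatter. Compound 3 is therefore estimated at 12000 nM in this assay, with a range from 3000 nM to 45000 nM.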

Compound 3, half-maximal inhibitory concentration: 17000 nM
For compound 3 the middle estimate is 1.4-fold (0.15 log units) below the measured one, and the stated range covers the measured number.
By their numbers in this assay, from the lowest: compound 1; then compound 3; then compound 2.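

In this assay, this is the first change shown at the amide-type nitrogen in a ring, and it gives a 2.1-fold higher number from compound 1 to compound 3 (0.31 log units; beyond the scatter), so what sits on this nitrogen does affect the number. The step removes a six-membered aromatic ring and a hydrogen-bond acceptor along with the 4-methoxyphenyl, yet it remains modest, so for this pair an aromatic ring on the nitrogen is not needed for a measurable number. Nothing measured here explains the step.

The compounds shown leave open whether a methyl group, a benzyl group or a chain ending in an amine on this nitrogen would give a lower or a higher number. As far as these compounds go, it is also open whether chloro in place of methoxy would give a similar step with isopropyl on the nitrogen.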